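Bromo in Place of Chloro: Expecting Compound 4

The source may hold more compounds than are shown below. What is called first, only, known or untested is meant among the compounds shown, and "the series" means these compounds.

Of the compounds shown here, three sharing one core have been measured in a functional assay on cardiac atrium for agonist activity at histamine H2 receptor (Cavia porcellus); a lower number here means a less potent compound, a higher number a more potent compound, by a factor of ten per unit of this negative logarithm. Compound 1 `N=C(NCCCc1c[nH]cn1)NCCC(c1ccccc1)c1ccccn1` gives 7.39. Compound 2 `N/C(=N\CCC(c1ccc(O)cc1)c1ccccn1)NCCCc1c[nH]cn1`, which carries a hydroxy on its phenyl ring, gives 6.63. Compound 3 `N=C(NCCCc1c[nH]cn1)NCCC(c1ccc(Cl)cc1)c1ccccn1` gives 7.84 and stands highest of the three, with compound 1 nearest and compound 2 furthest below it. Among the measured compounds shown here, the one step between compounds that differ in a single place, chloro in place of hydrogen on an aromatic carbon, reads a number 0.45 log units higher from compound 1 to compound 3 (beyond the scatter).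

Compound 4 `N=C(NCCCc1c[nH]cn1)NCCC(c1ccc(Br)cc1)c1ccccn1` has not been measured. It differs from compound 3 by bromo in place of chloro on an aromatic carbon. For the measured compounds named here, the only measured step that bears on it is the one from compound 1 to compound 3, in which a halogen entered at this position and this assay rose modestly. Exchanging one halogen for another is a smaller change than adding one, so for compound 4 the expected step in this assay is a number 0.06 log units higher from compound 3 to compound 4 (within the scatter), essentially none beyond the scatter. Compound 4 is therefore estimated at 7.9, expected to lie between 7.4 and 8.4.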

Compound 4, negative logarithm of the half-maximal effective concentration: 7.48
For compound 4 the middle estimate is 0.42 log units above the measured one, within the range that was stated.
By their numbers in this assay, from the lowest: compound 2; then compounds 1 and 4 (each within the scatter of the next); then compound 3.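

In this assay, bromo in place of chloro reads a number 0.36 log units lower from compound 3 to compound 4 (beyond the scatter) and so shows that these two halogens are not interchangeable at this position, even though a single heavy atom changes and the counted hydrogen-bond donors and acceptors stay the same. Bromo in place of hydrogen reads a number 0.09 log units higher from compound 1 to compound 4 (within the scatter) and stays within the scatter, so the gain seen with chloro does not extend to every halogen placed here. Nothing available here explains why chloro and bromo part ways.

From the compounds shown here alone, whether fluoro or methyl at this same place would stand nearer compound 3 or nearer compound 1 remains open. So does whether chloro and bromo would differ in the same way at another carbon of the phenyl ring.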